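Trimethoxyphenyl variant of the pyrimidine-linked acylurea series

A few compounds are considered here, and "the series" means these few. Any claim that something is new, unique, unknown or untested is made for them only; others in the source may bear on it.

Measured so far:
compound 1 `CC(C)c1ccc(-c2nc(SCc3cn(CC(=O)NC(=O)Nc4ccccn4)nn3)nc(Nc3ccccc3O)c2C#N)cc1` — 7380 nM
compound 2 `CC(C)c1ccc(Nc2nc(SCc3cn(CC(=O)NC(=O)Nc4ccccn4)nn3)nc(-c3ccc(C(C)C)cc3)c2C#N)cc1` — 2490 nM

Two compounds have numbers in a functional assay on ECa-109 cells (Homo sapiens) for inhibition, read by MTT assay, with a stated time of 72 h; a higher number here means a weaker inhibitor, a lower number a stronger inhibitor. Compound 1 gives 7380 nM and compound 2 gives 2490 nM. Among the compounds with values here, the one step available, a 3.0-fold lower number from compound 1 to compound 2 (0.47 log units; beyond the scatter), is the exchange of the group on the anilino nitrogen, and it places compound 2 as the lower of the two numbers.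

Compound 3 `COc1cc(-c2nc(SCc3cn(CC(=O)NC(=O)Nc4ccccn4)nn3)nc(Nc3ccc(C(C)C)cc3)c2C#N)cc(OC)c1OC` has not yet been measured. It differs from compound 2 in another place: 3,4,5-trimethoxyphenyl in place of 4-isopropylphenyl on an aromatic carbon. Within the data shown here, no measured step concerns this aromatic carbon; the only step known, a 3.0-fold lower number from compound 1 to compound 2 (0.47 log units; beyond the scatter), changes the group on the nitrogen and so gives no direct guide to what happens here. With nothing bearing on the change, the working expectation for compound 3 is a number in this assay close to that of compound 2, with a wide range on either side to cover the lack of a relevant precedent. The estimate for compound 3 is 2000 nM (range 600 nM to 7000 nM), which is an expected step of a 1.2-fold lower number from compound 2 to compound 3 (0.10 log units; within the scatter).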

Compound 3, half-maximal inhibitory concentration: > 64000 nM
Compound 3: only a limit was reported; the forecaster's own chance of this, stated with the estimate: 5%; middle value at least 32-fold (1.50 log units) away from the limit.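

In this assay compound 3 gives > 64000 nM, which is a limit of the assay and not a number. At the aromatic carbon ortho to a cyano group, the exchange of 4-isopropylphenyl for 3,4,5-trimethoxyphenyl gives an at least 25-fold higher number from compound 2 to compound 3 (1.40 log units; beyond the scatter), so this position is far from indifferent to the group it carries, and the step is larger than the earlier one on the nitrogen, a 3.0-fold lower number from compound 1 to compound 2 (0.47 log units; beyond the scatter). The exchange swaps a group with 0 hydrogen-bond acceptors for one with 3 and adds oxygen atoms, but this one pair cannot show which part of the change matters.

Still open, going by these compounds, is whether all three methoxy groups are needed for the loss, which a plain phenyl, a 4-methoxyphenyl or a 3,5-dimethoxyphenyl at this carbon would help to separate. Also open, on these data alone, is whether the gain seen on the nitrogen with 4-isopropylphenyl in place of 2-hydroxyphenyl carries over when another group sits on this carbon.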